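This account rests on a few compounds, and the source may have more. Where it says the series, first, only, none or still open, it means among the compounds named here.

Measured compounds:
Compound 1, `COc1ccc(C(=O)NCc2ccc(CNS(=O)(=O)c3ccc(C)cc3)cc2)cc1`: 100 nM
Compound 2, `COc1ccccc1C(=O)NCc1ccc(CNS(=O)(=O)c2ccc(C)cc2)cc1`: 100 nM

Both compounds were read in an assay on MDA-MB-231 cells for binding affinity to C-X-C chemokine receptor type 4 (Homo sapiens), read by immunofluorescence and microscopy, with stated times of 10 min and 30 min; on this read-out higher numbers stand for an effect only at larger amounts of compound and lower numbers for an effect already at smaller amounts. Compound 1 gives 100 nM in this assay, and compound 2 gives 100 nM. The one step between them, no change at the digits printed from compound 1 to compound 2 (within the scatter), so compound 2 stands level with compound 1 at the digits shown, and neither can be called the more potent of the pair.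

Compound 3, `Cc1ccc(S(=O)(=O)NCc2ccc(CNC(=O)c3ccccc3C)cc2)cc1`, has not yet been measured in this assay. It differs from compound 2 in one place: methyl in place of methoxy on an aromatic carbon. Cut one bond further out, the change reads 2-methoxyphenyl to 2-methylphenyl on the carbonyl carbon.

Going by the values given here, no measured step bears directly on this change. Among the compounds with values here, the only step available, from compound 1 to compound 2, concerns where the methoxy sits, not its replacement by methyl, and it was flat. The data therefore give no ground for a step beyond the scatter in either direction. The step from compound 2 to compound 3 is estimated as no change at the digits printed from compound 2 to compound 3 (within the scatter). Compound 3 is expected to give about 100 nM, with a range from 40 nM to 250 nM.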

Compound 3, effective concentration (reported as EC, without a stated level of effect): 100 nM
Beside the measured number, compound 3's estimate shows no gap at the digits printed; low and high end bracket the measured number.
By their numbers in this assay, from the lowest: compounds 1, 2 and 3 (each within the scatter of the next).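

In this assay, the earlier pair spoke only to where the methoxy sits, whereas the new result tests the group itself: the change to methyl on this aromatic carbon, ortho to a large group, gives no change at the digits printed from compound 2 to compound 3 (within the scatter) at this position. The swap removes one heavy atom and the one hydrogen-bond acceptor of the methoxy, yet the read-out shows no step beyond the scatter, so the oxygen is not required for the value seen here. Changing both the group and its place gives no change at the digits printed from compound 1 to compound 3 (within the scatter) and so adds no difference either, and no measurement at hand offers an explanation for this flat picture.

Going by these compounds, all three compounds stand level, so it remains open whether this position would respond to a different kind of group, such as a carboxylic acid, an amine or a longer chain like butoxy. On these data alone, it is also open whether a chlorine on the same aromatic carbon, or a change elsewhere in the shared core, would move the value beyond the scatter.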